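A few compounds are considered here, and "the series" means these few. Any claim that something is new, unique, unknown or untested is made for them only; others in the source may bear on it.

Measured in an ADME assay on MT4 cells (Homo sapiens) for cytotoxicity, read by MTT assay, with a stated time of 5 days; on this read-out lower numbers stand for higher toxicity in this test and higher numbers for lower toxicity in this test:
- compound 1 `Cc1cc(-c2ccc(C#N)cc2)cc(C)c1[C@H](O)c1ccnc(Nc2ccc(C#N)cc2)n1`: 5560 nM
- compound 2 `Cc1cc(-c2ccc(C#N)cc2)cc(C)c1C(O)c1ccnc(Nc2ccc(C#N)cc2)n1`: 6050 nM

Compound 2, at 6050 nM, stands level with compound 1 within the scatter. Moving to compound 3 `Cc1cc(-c2ccc(C#N)cc2)cc(C)c1[C@@H](O)c1ccnc(Nc2ccc(C#N)cc2)n1` gives (the two compounds have the same atoms and bonds; at least one stereo element is drawn with a configuration in one of them and without one in the other: 1 of 1 stereo elements differ; a stereocentre at a saturated chain carbon is drawn without a configuration in compound 2 and R in compound 3). Going by the values given here, the one measured step at this stereocentre is a 1.1-fold higher number from compound 1 to compound 2 (0.04 log units; within the scatter), with the fact that one of compounds 1 and 2 is drawn with a defined configuration and the other without, at the place where they differ as its only structural difference. No step beyond the scatter is therefore expected in this assay, and the expected change is a 1.0-fold lower number from compound 2 to compound 3 (0.00 log units; within the scatter). For compound 3 the estimate is 6000 nM, with an expected range of 3500 nM to 10500 nM.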

Compound 3, half-maximal cytotoxic concentration: 15000 nM
Compound 3: middle estimate off by 2.5-fold (0.40 log units), on the low side; the whole stated range lies below it.
By their numbers in this assay, from the lowest: compounds 1 and 2 (each within the scatter of the next); then compound 3.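

In this assay, the stereocentre at the saturated chain carbon now shows a step beyond the scatter: the R drawing gives a 2.7-fold higher number from compound 1 to compound 3 (0.43 log units; beyond the scatter), and also a 2.5-fold higher number from compound 2 to compound 3 (0.39 log units; beyond the scatter). Compound 3 thus stands apart from both compound 1 and compound 2, which the earlier pair, with no step beyond the scatter, could not show. The gap between the S and R drawings rests on configuration alone: the fact that compounds 1 and 3 differ only in the configuration as drawn.

As far as these compounds go, whether this gap persists with an amine in place of the hydroxyl stays open. Why configuration shifts this read-out also stays open.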